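Swapping Ethyl for Dimethylamino on a Sulfonyl Sulfur

The source may hold more compounds than are shown below. What is called first, only, known or untested is meant among the compounds shown, and "the series" means these compounds.

Compound 1 `CCS(=O)(=O)NC(=O)c1ccc(Nc2nc(NC3(c4ccc(Cl)cc4)CC3)nc(OCC(F)(F)F)n2)cc1` was tested in an ADME assay on microsomes from liver (Homo sapiens) for metabolic stability, with a stated time of 10 min (on this read-out lower numbers stand for a less stable compound and higher numbers for a more stable compound), where compound 1 gives 100%. Its nearest neighbour, compound 2 `NCCS(=O)(=O)NC(=O)c1ccc(Nc2nc(NC3(c4ccc(Cl)cc4)CC3)nc(OCC(F)(F)F)n2)cc1`, gives 100% in this assay, and the step of no change at the digits printed from compound 1 to compound 2 (within the scatter) stays within the scatter. Compound 3 `CN(C)S(=O)(=O)NC(=O)c1ccc(Nc2nc(NC3(c4ccc(Cl)cc4)CC3)nc(OCC(F)(F)F)n2)cc1` differs from compound 1 in one place: dimethylamino in place of ethyl on a sulfonyl sulfur. Among the measured compounds shown here, the single measured step did not touch the sulfonyl sulfur, so it offers only a weak hint; still, both measured compounds stand level at the same reading, and no change beyond the scatter is expected, no change at the digits printed from compound 1 to compound 3 (within the scatter). Compound 3 is therefore estimated at 100%, within a range from 88% to 100%.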

Compound 3, percent of the compound remaining: 86%
The estimate for compound 3 lay 14 percentage points above the measured number; measured number below the stated range.
By their numbers in this assay, from the lowest: compound 3; then compounds 1 and 2 (each within the scatter of the next).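

At this position the group on the sulfonyl sulfur does affect the reading in this assay: dimethylamino in place of ethyl gives a number 14 percentage points lower from compound 1 to compound 3 (beyond the scatter) here. Dimethylamino in place of 2-aminoethyl gives a number 14 percentage points lower from compound 2 to compound 3 (beyond the scatter) as well, so these are the first steps in the set that go beyond the scatter. Nothing available explains this lower number.

On these data alone, whether it follows from the nitrogen on the sulfonyl sulfur or from the two methyl groups stays open. A plain amino group or a methylamino group at this place would help to tell these apart.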